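The compounds below may be only part of what the source reports. "The series", "measured", "known", "first", "only" and "open" are said of these compounds alone.

Measured so far:
compound 1, `COc1ccc(C2C(C#N)=C(N)N(c3cc(OC)c(OC)c(OC)c3)C3=C2C(=O)CC(C)(C)C3)cc1` — 1%
compound 2, `COc1cc(N2C(N)=C(C#N)C(/C=C/c3ccccc3)C3=C2CC(C)(C)CC3=O)cc(OC)c1OC` — 30%
compound 3, `COc1cc(N2C(N)=C(C#N)C(c3ccc(Cl)cc3Cl)C3=C2CC(C)(C)CC3=O)cc(OC)c1OC` — 55%

In a functional assay on Ehrlich cells (Mus musculus) for cytotoxicity, tested at 25 ug/mL (on this read-out higher numbers stand for a stronger effect at the one concentration tested and lower numbers for a weaker effect), compound 3 stands highest of the three, with compound 2 nearest and compound 1 furthest; the step of a number 54 percentage points higher from compound 1 to compound 3 (beyond the scatter) is large, and the step of a number 25 percentage points higher from compound 2 to compound 3 (beyond the scatter) is modest, both beyond the scatter. Compound 4, `COc1cc(N2C(N)=C(C#N)C(c3ccccc3Cl)C3=C2CC(C)(C)CC3=O)cc(OC)c1OC`, has not yet been measured. It differs from compound 3 in one place: hydrogen in place of chloro on an aromatic carbon. Cut one bond further out, the change reads 2,4-dichlorophenyl to 2-chlorophenyl.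

Within the data shown here, no measured step removes a single chloro from this ring. Among the measured compounds shown here, the steps that bear on it only show that the 2,4-dichlorophenyl group carries the highest number of the set, each alternative aryl or alkenyl group on that saturated ring carbon sitting lower: a number 54 percentage points higher from compound 1 to compound 3 (beyond the scatter) and a number 25 percentage points higher from compound 2 to compound 3 (beyond the scatter). Since the aryl group is partly kept, compound 4 is expected to lose some but not all of that standing in a modest downward step that is estimated as a number 15 percentage points lower from compound 3 to compound 4 (beyond the scatter). Compound 4 is therefore estimated at 40%, within 15% to 65%.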

Compound 4, a percentage reported as activity, at one concentration (the size of the read-out at that concentration, not a potency): 15%
Compound 4: middle estimate off by 25 percentage points, on the high side; measured number inside the range.
By their numbers in this assay, from the lowest: compound 1; then compound 4; then compound 2; then compound 3.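

In this assay, removing one chloro from the 2,4-dichlorophenyl group gives a number 40 percentage points lower from compound 3 to compound 4 (beyond the scatter), so this single chloro, para to a large group, carries much of that group's standing. With a number 15 percentage points lower from compound 2 to compound 4 (beyond the scatter), the remaining 2-chlorophenyl group also sits under the 2-phenylethenyl group at the saturated ring carbon. Yet a number 14 percentage points higher from compound 1 to compound 4 (beyond the scatter) keeps it over the 4-methoxyphenyl group, so the chlorinated aryl group alone does not decide the order among these compounds. No measured evidence here accounts for the size of the loss.

From the compounds shown here alone, what stays open is whether bromo, fluoro or an amine on that same aromatic carbon would hold the number. Going by these compounds, it is also open whether the chloro that left would keep its effect on a ring without the other chloro.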